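The source may hold more compounds than are shown below. What is called first, only, known or untested is meant among the compounds shown, and "the series" means these compounds.

Measured compounds: compound 1 `CC1CCCCC1N(CCCCCCN1C[C@H](O)[C@@H](O)[C@H](O)[C@H]1CO)C(=O)OC(C)(C)C` in an ADME assay on Huh-7 cells (Homo sapiens) for cytotoxicity, read by MTT assay (on this read-out higher numbers stand for lower toxicity in this test and lower numbers for higher toxicity in this test), gives 240000 nM. Compound 2 `CC(C)(C)C(=O)N(CCCCCCN1C[C@H](O)[C@@H](O)[C@H](O)[C@H]1CO)c1cc(F)ccc1F` gives only a limit in this assay, > 500000 nM.

Compound 2 therefore stands at the edge of what this assay reports, at the limit of > 500000 nM in this assay, at which 1 of the 2 values shown sits; how far beyond it lies is not known. Compound 3 `CC(C)(C)C(=O)N(CCCCCCN1C[C@H](O)[C@@H](O)[C@H](O)[C@H]1CO)C1CCCCCCC1` differs by cyclooctyl in place of 2,5-difluorophenyl on an amide-type nitrogen. Going by the values given here, no measured pair shows this change, so the step of an at least 1.6-fold lower number from compound 2 to compound 3 (0.22 log units; that floor lies within the scatter) is only an expectation: small, within the scatter, or towards slightly higher toxicity. Compound 3 is expected to give 300000 nM, with a range from 120000 nM to 600000 nM.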

Compound 3, half-maximal cytotoxic concentration: 150000 nM
For compound 3 the middle estimate is 2.0-fold (0.30 log units) above the measured one; low and high end bracket the measured number.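

In this assay, the two compounds differ only in the ring on the amide-type nitrogen, and cyclooctyl in place of 2,5-difluorophenyl gives an at least 3.3-fold lower number from compound 2 to compound 3 (0.52 log units; beyond the scatter). This shows that the group at this place can shift the read-out towards higher toxicity in this test, even with the same number of heavy atoms. The true size of the step is unknown because compound 2 gives only a limit: the limit of > 500000 nM in this assay, at which 1 of the 3 values shown sits.

As far as these compounds go, whether the fluorines, the aromatic ring or the ring size matters stays open. A plain phenyl or a cyclopentyl at this place would help to separate these.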